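Methyl in Place of Fluoro on the Carbonyl Aryl Ring

A few compounds are considered here, and "the series" means these few. Any claim that something is new, unique, unknown or untested is made for them only; others in the source may bear on it.

Compound 2 `COc1cc(N(Cc2nc3ccccc3[nH]2)C(=O)c2ccc(F)cc2)cc(OC)c1OC` gives 23600 nM in a functional assay on MGC-803 cells (Homo sapiens) for inhibition, read by MTT assay, with a stated time of 48 h (on this read-out higher numbers stand for weaker inhibition and lower numbers for stronger inhibition), the higher of the two numbers measured, and stands beyond the scatter from compound 1 `COc1cc(N(Cc2nc3ccccc3[nH]2)S(=O)(=O)c2ccc(C)cc2)cc(OC)c1OC`, which gives 1020 nM. Among the compounds with values here, the single measured step, a 23-fold higher number from compound 1 to compound 2 (1.36 log units; beyond the scatter), was large, but it exchanged the whole group on the ring nitrogen, (4-methylphenyl)sulfonyl for (4-fluorophenyl)carbonyl. Compound 3 `COc1cc(N(Cc2nc3ccccc3[nH]2)C(=O)c2ccc(C)cc2)cc(OC)c1OC` differs from compound 2 in one place: methyl in place of fluoro on an aromatic carbon. Within the data shown here, no measured step covers an exchange of this kind, since the two compounds that have been measured differ in the group on the nitrogen and not in the substituent on the six-membered aromatic ring of carbon only. Without such a comparison, the expected step is a 1.2-fold lower number from compound 2 to compound 3 (0.07 log units; within the scatter), that is, nothing beyond the scatter, while a modest move in either direction is left open by the range. Compound 3 is therefore expected to give 20000 nM in this assay, within a range of 6000 nM to 60000 nM.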

Compound 3, half-maximal inhibitory concentration: 30500 nM
The estimate for compound 3 lay 1.5-fold (0.18 log units) below the measured number; the range from low to high includes it.
By their numbers in this assay, from the lowest: compound 1; then compounds 2 and 3 (each within the scatter of the next).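

In this assay, methyl for fluoro on the aromatic carbon para to a large group gives a 1.3-fold higher number from compound 2 to compound 3 (0.11 log units; within the scatter) and so, with a carbonyl on the nitrogen, these two substituents cannot be told apart at this position. With the 4-methylphenyl group now held fixed on both sides, the exchange of sulfonyl for carbonyl can be read alone as a 30-fold higher number from compound 1 to compound 3 (1.48 log units; beyond the scatter) and this large step shows that the weaker inhibition seen with the carbonyl compounds does not depend on a change of the substituent on the aromatic ring. No measurement at hand bears on the cause of either step.

The compounds shown leave open whether the position para to a large group stays as unresponsive with groups of another kind, such as an amine, a carboxylic acid or a longer alkyl chain. They also leave open whether fluoro and methyl would remain within the scatter of each other on the sulfonyl side, where a 4-fluorophenylsulfonyl group would give the matching comparison with compound 1 .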